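This account rests on a few compounds, and the source may have more. Where it says the series, first, only, none or still open, it means among the compounds named here.

Measured compounds in an ADME assay on HEK293 cells (Homo sapiens) for cytotoxicity, read by MTT assay, with a stated time of 36 h; on this read-out lower numbers stand for stronger inhibition and higher numbers for weaker inhibition:

Compound 1 `O=C(c1ccc2c(c1)OCCO2)C1CCN(Cc2coc(-c3ccc(F)cc3)n2)CC1` gives > 150 ug/mL, a limit of this assay rather than a number.
Compound 2 `O=C(c1ccc2c(c1)OCCO2)C1CCN(Cc2coc(-c3ccccc3F)n2)CC1` gives > 150 ug/mL, likewise a limit.
Compound 3 `O=C(c1ccc2c(c1)OCCO2)C1CCN(Cc2coc(-c3cccnc3)n2)CC1` gives > 150 ug/mL, again a limit.

Compound 1 therefore stands at the top of what this assay reports, and its two companions stand at the same limit, as the limit of > 150 ug/mL in this assay, at which 3 of the 3 values shown sit, records. The steps among them, a step that the two limits leave unreadable from compound 1 to compound 2, a step that the two limits leave unreadable from compound 1 to compound 3 and a step that the two limits leave unreadable from compound 2 to compound 3, cannot be sized because each end sits at that limit; all three aryl groups on the shared core of compound 1 leave cytotoxicity undetected.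

Compound 4 `O=C(c1ccc2c(c1)OCCO2)C1CCN(Cc2coc(-c3ccoc3)n2)CC1` differs from compound 1 in one place: furan-3-yl in place of 4-fluorophenyl on an aromatic carbon. The measured steps that bear on it are those three unreadable steps, which show only that swapping 4-fluorophenyl for 2-fluorophenyl or pyridin-3-yl left the read-out at the limit. Since none of them is sized, no step beyond the scatter is expected in this assay, in either direction.

The estimate for compound 4 is therefore 200 ug/mL, with a range from 120 ug/mL to 350 ug/mL, and the step from compound 1 is expected to be a step that the limit leaves unreadable from compound 1 to compound 4, most likely again reported only as a limit.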

Compound 4, half-maximal inhibitory concentration: > 150 ug/mL
Compound 4: only a limit was reported; the forecaster's own chance of this, stated with the estimate: 85%; the middle value lies beyond the limit too.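

In this assay compound 4 gives > 150 ug/mL as a limit and not a number. No step can be read between compound 4 and compound 1, compound 2 or compound 3, since all four share one limit: the limit of > 150 ug/mL in this assay, at which 4 of the 4 values shown sit. The compounds shown leave open how these four groups on the shared core would rank, and at what concentration any would show cytotoxicity.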